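One added methoxy group on compound 2

A few compounds are considered here, and "the series" means these few. Any claim that something is new, unique, unknown or untested is made for them only; others in the source may bear on it.

Of the compounds shown here, two sharing one core have numbers so far. In a functional assay on A549 cells (Homo sapiens) for antiproliferative activity, read by sulforhodamine B assay, with a stated time of 48 h (on this read-out lower numbers stand for stronger inhibition and higher numbers for weaker inhibition), compound 1 (`COc1ccc2nc(-c3ccc(N/C=C\C(=O)c4cc(OC)c(OC)c(OC)c4)cc3)sc2c1`) gives 12100 nM, and compound 2 (`COc1ccc2nc(-c3ccc(N/C=C\C(=O)c4ccc(OC)c([N+](=O)[O-])c4)cc3)sc2c1`) gives 13600 nM. Within the data shown here, these two values lie within the scatter of each other, so compound 2 stands level with the only other measured compound, and the data do not rank the pair.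

Compound 3 (`COc1ccc2nc(-c3ccc(N/C=C\C(=O)c4cc(OC)c(OC)c([N+](=O)[O-])c4)cc3)sc2c1`) is compound 2 with a single change: methoxy in place of hydrogen on an aromatic carbon. It is methoxy in place of hydrogen on an aromatic carbon, ortho to a methoxy group and meta to a nitro group.

Among the measured compounds shown here, no measured pair shows this change alone, so its size in this assay cannot be read directly. For the measured compounds named here, the only guide is that compound 1, at 12100 nM, and compound 2, at 13600 nM, carry different groups on that aromatic ring and still sit within the scatter. Compound 3 carries methoxy and nitro groups, both already present in that pair, so no step beyond the scatter is expected in either direction. The estimated step of a 1.1-fold lower number from compound 2 to compound 3 (0.04 log units; within the scatter) is expected to be small. The estimate for compound 3 is 12500 nM, with an expected range from 6000 nM to 26000 nM.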

Compound 3, half-maximal inhibitory concentration: 21600 nM
Estimate against measurement, compound 3: 1.7-fold (0.24 log units) below, within the range that was stated.
By their numbers in this assay, from the lowest: compounds 1, 2 and 3 (each within the scatter of the next).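

This change now has a direct reading: in this assay, methoxy in place of hydrogen on an aromatic carbon, ortho to a methoxy group and meta to a nitro group, gives a 1.6-fold higher number from compound 2 to compound 3 (0.20 log units; within the scatter), so this added group produces no step beyond the scatter. The same ring also gains a second single-change comparison, nitro in place of methoxy on an aromatic carbon, which gives a 1.8-fold higher number from compound 1 to compound 3 (0.25 log units; within the scatter) and also stays within the scatter, so neither change separates the compounds that carry it. No measurement here bears on why these numbers lie so close together.

All three compounds carry only methoxy and nitro groups on this ring, so the data say nothing about how an amine, a hydroxyl group, a carboxylic acid or a longer alkoxy chain on the same aromatic carbon would read in this assay. As far as these compounds go, it also remains open whether any change on this ring can move the number beyond the scatter, or whether a change elsewhere on the shared core would do so.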